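Quinoline amide to phenylurea in a urotensin receptor series

The compounds below may be only part of what the source reports. "The series", "measured", "known", "first", "only" and "open" are said of these compounds alone.

Compound 1: `CN(C)CCCOc1ccc(CN2CC[C@H](NC(=O)c3ccc(-c4ccccc4)cc3)C2)cc1`. In an assay on HEK293 cells for binding affinity to Urotensin-2 receptor (Homo sapiens), read by radioligand binding (a lower number here means a stronger inhibitor, a higher number a weaker inhibitor), compound 1 gives < 10000 nM, which is a limit of the assay and not a number.
Compound 2: `CC(C)C[C@H](NC(=O)c1ccc2ccccc2n1)C(=O)N[C@H]1CCN(Cc2ccc(OCCCN(C)C)cc2)C1`. In this assay compound 2 gives 631 nM.

Compound 2 stands on the only number shown; the other entry is a limit (the limit of < 10000 nM in this assay, at which 1 of the 2 values shown sits). Compound 3 `CC(C)C[C@H](NC(=O)Nc1ccccc1)C(=O)N[C@H]1CCN(Cc2ccc(OCCCN(C)C)cc2)C1` has not yet been measured. It differs from compound 2 in one place: anilino in place of quinolin-2-yl on a carbonyl carbon. For the measured compounds named here, no step between measured compounds is available to size such a change, and the quinolin-2-yl group replaced here is the larger, two-ring part of compound 2. The expectation is a step toward weaker inhibition, somewhat beyond the usual scatter, as a 3.2-fold higher number from compound 2 to compound 3 (0.50 log units; beyond the scatter). Compound 3 is expected to come in around 2000 nM, with an estimated range from 500 nM to 8000 nM.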

Compound 3, inhibition constant: 1000 nM
Beside the measured number, compound 3's estimate is 2.0-fold (0.30 log units) above it; the range from low to high includes it.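

In this assay, placing anilino instead of quinolin-2-yl on the carbonyl carbon gives a 1.6-fold higher number from compound 2 to compound 3 (0.20 log units; within the scatter). In this one pair, then, the two-ring group gives way to a group with a single carbon-only aromatic ring, and a hydrogen-bond acceptor gives way to a hydrogen-bond donor, with no change beyond the usual scatter. Nothing in the data shown accounts for the size of this step.

Still open, as far as these compounds go, is whether a chlorine or a methoxy group on the anilino group, or a benzylamino group in its place, would move the number beyond the scatter. Compound 1 differs from compound 2 and compound 3 in more than one place, so steps to it cannot be read.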